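The compounds below may be only part of what the source reports. "The series", "measured", "known", "first", "only" and "open" are said of these compounds alone.

For the measured compounds named here, compound 3 `Cn1ccc2ccc(-c3cc(Nc4cnccc4C(=O)NC4CCNC(=O)C4)cc4nccnc34)cc21` is one of three compounds measured in a physicochemical assay for solubility, read by spectrophotometry, measured as kinetic solubility, at pH 8, tested at 500 uM; on this read-out lower numbers stand for lower solubility and higher numbers for higher solubility. In this assay compound 3 gives 242 ug/mL, the second highest of the three numbers. Compound 2 `Cn1ccc2ccc(-c3cc(Nc4ccccc4S(=O)(=O)Nc4cncnc4)cc4nccnc34)cc21` gives 254 ug/mL, which lies within the scatter of compound 3, so the two cannot be ordered. Compound 1 `CNS(=O)(=O)c1ccccc1Nc1cc(-c2ccc3ccn(C)c3c2)c2nccnc2c1` gives 2 ug/mL, far below both. Going by the values given here, the one measured step, a 130-fold higher number from compound 1 to compound 2 (2.10 log units; beyond the scatter), comes from a change on a sulfonamide nitrogen and does not touch the part of the molecule that changes here.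

Compound 4 `CC(=O)N1CCC(NC(=O)c2ccncc2Nc2cc(-c3ccc4ccn(C)c4c3)c3nccnc3c2)C1` differs from compound 3 in one place: 1-acetylpyrrolidin-3-yl in place of 2-oxopiperidin-4-yl on an amide-type nitrogen. Among the compounds with values here, no measured step covers a change on an amide-type nitrogen, so the only guide is the value of compound 3 itself. Within the data shown here, because compound 3 sits at 242 ug/mL and the change is remote from the site of the one measured step, compound 4 is expected to land near compound 3, the step of a 1.6-fold lower number from compound 3 to compound 4 (0.21 log units; within the scatter) likely within the scatter or a little downward. Compound 4 is estimated at 150 ug/mL, with a range from 40 ug/mL to 320 ug/mL.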

Compound 4, solubility: 253 ug/mL
Estimate against measurement, compound 4: 1.7-fold (0.23 log units) below, within the range that was stated.
By their numbers in this assay, from the lowest: compound 1; then compounds 3, 4 and 2 (each within the scatter of the next).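

In this assay, for the compounds shown here, the first measured step at this amide-type nitrogen, 1-acetylpyrrolidin-3-yl in place of 2-oxopiperidin-4-yl, is a 1.0-fold higher number from compound 3 to compound 4 (0.02 log units; within the scatter). The earlier step lay on a sulfonamide nitrogen, so this position had no reading of its own until now, and the two groups here cannot be told apart by this read-out. That holds even though the entering group has a five-membered non-aromatic ring and 0 hydrogen-bond donors, while the leaving group has a six-membered non-aromatic ring and 1 hydrogen-bond donor, and no measurement explains this outcome.

Both groups shown on this nitrogen contain a non-aromatic ring with 1 hetero atom and a carbonyl. As far as these compounds go, it remains open whether a group of another kind there, such as a free amine, a carboxylic acid or a longer open chain, would leave the number as unchanged.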